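This account rests on a few compounds, and the source may have more. Where it says the series, first, only, none or still open, it means among the compounds named here.

Working notes on the series. The three measured compounds share one core and differ only in the group on the outer aromatic ring. Compound 1 `COc1ccc(/C=C2/CN(C)/C(=N/c3ccc(C)cc3)S2)cc1` gives 7600 nM in a functional assay on MCF7 cells (Homo sapiens) for antiproliferative activity, read by MTT assay, with a stated time of 72 h; on this read-out lower numbers stand for stronger inhibition and higher numbers for weaker inhibition. Compound 2 `COc1ccc(/C=C2/CN(C)/C(=N/c3ccc(Cl)cc3)S2)cc1` gives 7600 nM in this assay, and compound 3 `COc1ccc(/C=C2/CN(C)/C(=N/c3ccc(OC)cc3)S2)cc1` gives 8700 nM. The steps among them are no change at the digits printed from compound 1 to compound 2 (within the scatter), a 1.1-fold higher number from compound 1 to compound 3 (0.06 log units; within the scatter) and a 1.1-fold higher number from compound 2 to compound 3 (0.06 log units; within the scatter); compound 3 thus stands level with the other two, none of the gaps exceeding the scatter.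

Compound 4 `COc1ccc(/C=C2/CN(C)/C(=N/c3ccc([N+](=O)[O-])cc3)S2)cc1` carries the next exchange at that same aromatic carbon: nitro in place of methoxy on an aromatic carbon. Among the measured compounds shown here, the steps that bear on it are the three exchanges already measured at this place, no change at the digits printed from compound 1 to compound 2 (within the scatter), a 1.1-fold higher number from compound 1 to compound 3 (0.06 log units; within the scatter) and a 1.1-fold higher number from compound 2 to compound 3 (0.06 log units; within the scatter), each of which left this assay unchanged within the scatter. A fourth exchange at the same place is therefore expected to give no step beyond the scatter, estimated as a 1.1-fold lower number from compound 3 to compound 4 (0.04 log units; within the scatter). Compound 4 is expected to give 8000 nM in this assay, within a range from 3500 nM to 18000 nM.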

Compound 4, half-maximal inhibitory concentration: 9800 nM
Estimate against measurement, compound 4: 1.2-fold (0.09 log units) below, and the stated range covers the measured number.
By their numbers in this assay, from the lowest: compounds 1, 2, 3 and 4 (each within the scatter of the next).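

The exchange to nitro stays within the scatter in this assay against each earlier group at this aromatic carbon: a 1.1-fold higher number from compound 3 to compound 4 (0.05 log units; within the scatter), a 1.3-fold higher number from compound 2 to compound 4 (0.11 log units; within the scatter) and a 1.3-fold higher number from compound 1 to compound 4 (0.11 log units; within the scatter). The level behaviour at this place therefore extends beyond methyl, chloro and methoxy to a group with a double bond outside aromatic rings and more hydrogen-bond acceptors than methoxy, so four different groups here give no step beyond the scatter. No available evidence accounts for this flat result.

From the compounds shown here alone, it remains open whether an amine, a carboxylic acid or a longer chain at this carbon would produce a step beyond the scatter. Also open, going by these compounds, is whether an exchange elsewhere on the shared core would move the number further than any exchange at this place.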